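Adding a methoxy to compound 2: a cytotoxicity estimate

A few compounds are considered here, and "the series" means these few. Any claim that something is new, unique, unknown or untested is made for them only; others in the source may bear on it.

Compound 1 `COc1ccc(-c2nc3cc(C(C)=O)ccc3[nH]2)c(OC)c1` - 50000 nM
Compound 2 `COc1ccc(-c2nc3cc(/C(C)=N/NC(N)=O)ccc3[nH]2)cc1` - "not determined" (no result reported)

Going by the values given here, in an ADME assay on BHK-21 cells (Mesocricetus auratus) for cytotoxicity, read by MTT assay (on this read-out higher numbers stand for lower toxicity in this test and lower numbers for higher toxicity in this test), compound 1 gives 50000 nM, and this is the only number available so far. Compound 2 has no single number to stand on, since its entry reads "not determined" (no result reported), so it offers no measured starting point and cannot be ranked against compound 1.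

The next structure is compound 3 `COc1ccc(-c2nc3cc(/C(C)=N/NC(N)=O)ccc3[nH]2)c(OC)c1`. The structural change is methoxy in place of hydrogen on an aromatic carbon. Among the compounds with values here, no measured pair in this small set shows what such a change does, and no step from the starting structure can be sized directly. In this assay the expectation is therefore no step beyond the usual scatter, in either direction. Compound 1 also carries the entering methoxy but differs elsewhere, so its 50000 nM is only a loose guide. For compound 3 the expected half-maximal cytotoxic concentration is estimated at 40000 nM, with a likely range from 10000 nM to 150000 nM.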

Compound 3, half-maximal cytotoxic concentration: >= 100000 nM
Compound 3: no number, only a limit (the forecaster's own chance of this, stated with the estimate: 30%); at least 2.5-fold (0.39 log units) between middle value and limit.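

In this assay compound 3 gives a limit of the assay and not a number, >= 100000 nM, and it is the only read-out shown that joins the methoxy group to the group of 7 heavy atoms. With the methoxy on the aromatic carbon ortho to a large group held the same, a group of 7 heavy atoms in place of a group of 3 heavy atoms gives an at least 2.0-fold higher number from compound 1 to compound 3 (0.30 log units; that floor lies within the scatter), so this exchange is not seen to push the read-out towards lower numbers, though the floor of the step does not clear the usual scatter. How far the true figure for compound 3 lies past its limit stays unfixed: the limit of >= 100000 nM in this assay, at which 1 of the 3 values shown sits.

The methoxy itself remains unsized: compound 2 has no result, and the step from compound 2 to compound 3 cannot be read, so the compounds shown do not say whether hydrogen or methoxy at this carbon matters in this test. Nor do they show how an ethoxy group, a fluorine atom or an amine on the same aromatic carbon would read, or what a longer chain in place of the group of 7 heavy atoms would do.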